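The source may report more compounds than this note shows. Statements on the series, on what has been measured and on what is new or still open speak of the compounds shown alone.

For the measured compounds named here, in a functional assay on K562 cells (Homo sapiens) for antiproliferative activity, with a stated time of 48 h (a higher number here means a weaker inhibitor, a lower number a stronger inhibitor), compound 1 (`Cc1cc(=O)c2c(O)cc(OCC3CO3)cc2o1`) gives 143000 nM as the higher of the two numbers so far, while compound 2 (`Cc1cc(=O)c2c(OCC3CO3)cc(OCC3CO3)cc2o1`) gives 6300 nM as the lower. Compound 3 (`Cc1cc(=O)c2c(O)cc(OC[C@H]3CO3)cc2o1`) has not yet been measured, and it differs from compound 1 in one way only (the two compounds have the same atoms and bonds; at least one stereo element is drawn with a configuration in one of them and without one in the other: 1 of 1 stereo elements differ; a stereocentre at a saturated ring carbon is drawn without a configuration in compound 1 and R in compound 3). Going by the values given here, the single measured step (a 23-fold lower number from compound 1 to compound 2 (1.36 log units; beyond the scatter)) is large, but it changes the atoms, whereas here the atoms and bonds stay the same, so it offers little guidance. No step beyond the scatter is therefore expected (a 1.1-fold lower number from compound 1 to compound 3 (0.04 log units; within the scatter)). In this assay the estimated value for compound 3 is 130000 nM with an expected range from 60000 nM to 280000 nM around it.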

Compound 3, half-maximal inhibitory concentration: 9740 nM
The estimate for compound 3 lay 13-fold (1.13 log units) above the measured number; measured number outside the range, below it.
By their numbers in this assay, from the lowest: compounds 2 and 3 (each within the scatter of the next); then compound 1.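

In this assay, a change that leaves every atom and bond in place still gives a large step, a 15-fold lower number from compound 1 to compound 3 (1.17 log units; beyond the scatter). Earlier, only a change of atoms had shown a step beyond the scatter, so the configuration at this saturated ring carbon matters here as well. The one difference the two structures record is this: the fact that one of compounds 1 and 3 is drawn with a defined configuration and the other without, at the place where they differ

Going by these compounds, whether compound 1 stands for a mixture of forms remains open, as does how the S configuration would compare. Also open, on these data alone, is what an amine in place of the (oxiran-2-yl)methyl would give.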